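Vinyl Gives Way to (Neopentylcarbonyl)amino

A few compounds are considered here, and "the series" means these few. Any claim that something is new, unique, unknown or untested is made for them only; others in the source may bear on it.

Compound 1 `C=Cc1cccc(C(=O)N2CCCC(C(=O)Nc3ccc(Cl)cc3)C2)c1` shows no measurable cytotoxic effect in an ADME assay on PC-3 cells (Homo sapiens) for cytotoxicity, read by WST assay, tested at 100 uM (on this read-out higher numbers stand for more inhibition at the one concentration tested (going by the name of the read-out) and lower numbers for less inhibition), where compound 1 gives 0%. Compound 2 `CC(=O)c1cccc(NC(=O)C2CCCN(C(=O)c3cc(C(F)(F)F)cc(C(F)(F)F)c3)C2)c1` stands level with it at the digits shown; in this assay compound 2 gives 0%. Compound 3 `CC(C)(C)CC(=O)Nc1cccc(C(=O)N2CCCC(C(=O)Nc3ccc(Cl)cc3)C2)c1` differs from compound 1 by (neopentylcarbonyl)amino in place of vinyl on an aromatic carbon. Among the measured compounds shown here, no step between measured compounds is known, and both measured values sit at the floor of the read-out, so the step of a number 3 percentage points higher from compound 1 to compound 3 (within the scatter) is expected to remain within the scatter, in no particular direction. Compound 3 is accordingly estimated at 3%, with a range from 0% to 15%.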

Compound 3, a percentage reported as inhibition, at one concentration (the size of the read-out at that concentration, not a potency): 0%
For compound 3 the middle estimate is 3 percentage points above the measured one; the range from low to high includes it.
By their numbers in this assay, from the lowest: compounds 1, 2 and 3 (each within the scatter of the next).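

In this assay, among the compounds shown here, (neopentylcarbonyl)amino in place of vinyl on this aromatic carbon gives no change at the digits printed from compound 1 to compound 3 (within the scatter), the first step that can be read at this position. The entering group is the larger of the two and brings a hydrogen-bond donor and acceptor, yet the read-out stays at its floor, so the step does not show how far this position could move it. Nothing at hand bears on this result. As far as these compounds go, whether an amine or a carboxylic acid on this aromatic carbon would lift the read-out remains open.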